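This account rests on a few compounds, and the source may have more. Where it says the series, first, only, none or still open, it means among the compounds named here.

Of the compounds shown here, three built on one shared core have been measured in a physicochemical assay for lipophilicity, read by HPLC, measured as octanol-water partition; a lower number here means a more polar compound, a higher number a more lipophilic compound. Compound 1, `COc1ccc(N(CC(=O)NCCC[Se]c2ccccc2)C(=O)CNC(=O)OC(C)(C)C)cc1`, gives 3.3 in this assay. Compound 2, `COc1ccc(N(CC(=O)NCCCSc2ccccc2)C(=O)/C=C/c2ccccc2)cc1`, gives 4. Compound 3, `COc1ccc(N(CC(=O)NCCC[Se]c2ccccc2)C(=O)C#Cc2ccccc2)cc1`, gives 2.6, the lowest of the three numbers; compound 1 sits nearest to it and compound 2 furthest away, both beyond the scatter. Going by the values given here, the only single-change step that has been measured, a number 0.70 log units lower from compound 1 to compound 3 (beyond the scatter), concerns the group on the carbonyl carbon and not the end of the chain.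

Compound 4, `COc1ccc(N(CC(=O)NCCCSc2ccccc2)C(=O)C#Cc2ccccc2)cc1`, has not yet been measured in this assay. It differs from compound 3 by a group of 7 heavy atoms (6 carbon, 1 sulfur; one six-membered aromatic ring of carbon only) in place of a group of 7 heavy atoms (6 carbon, 1 selenium; one six-membered aromatic ring of carbon only), on a saturated chain carbon, three bonds along the chain from an amide-type nitrogen. Among the compounds with values here, no measured pair isolates this exchange. Compound 2 carries the phenylsulfanyl group, but it also carries a different group on the carbonyl carbon, so the gap between compound 2 and compound 3 mixes two changes and cannot be split into parts. Within the data shown here, with no step bearing directly on the swap of selenium for sulfur, and the two groups matched in heavy atoms and rings, the expected step is one that stays within the scatter, leaning if anything slightly downward, a number 0.20 log units lower from compound 3 to compound 4 (within the scatter). The estimate for compound 4 in this assay is therefore 2.4, with a range from 1.9 to 2.9.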

Compound 4, partition coefficient: 3.4
Estimate against measurement, compound 4: 1.00 log units below; the whole stated range lies below it.
By their numbers in this assay, from the lowest: compound 3; then compounds 1 and 4 (each within the scatter of the next); then compound 2.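

In this assay, placing sulfur where selenium stood, on a saturated chain carbon, three bonds along the chain from an amide-type nitrogen, gives a number 0.80 log units higher from compound 3 to compound 4 (beyond the scatter) even though the two groups match in heavy atoms and ring. This position therefore responds to the identity of that single element, and the end of the chain can shift the number by a step beyond the scatter, just as the group on the carbonyl carbon can. That second position also gains a cleaner reading, with 2-phenylethynyl in place of 2-phenylethenyl giving a number 0.60 log units lower from compound 2 to compound 4 (beyond the scatter) while the phenylsulfanyl group stays fixed. No measurement shown here explains why either step takes the direction it does.

As far as these compounds go, the selenium and sulfur exchange has been read only with 2-phenylethynyl on the carbonyl carbon, so its size with ((tert-butoxycarbonyl)amino)methyl or 2-phenylethenyl there remains open. Also open, from the compounds shown here alone, is how the number would respond to an oxygen atom in place of the sulfur or selenium, or to a longer chain at this position.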